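Trimming a methyl from the aromatic amine of compound 1

The source may report more compounds than this note shows. Statements on the series, on what has been measured and on what is new or still open speak of the compounds shown alone.

The compounds share one core carrying a sugar, and they differ in the group on the ring carbon and in the substituent on the aromatic nitrogen. Compound 1 `CN(C)c1ncnc2c1c(-c1cc3ccccc3o1)cn2[C@@H]1O[C@H](CO)[C@@H](O)[C@H]1O` carries a 1-benzofuran-2-yl group and a dimethylamino group. In a functional assay on CCRF-CEM cells (Homo sapiens), read by MTT assay, with a stated time of 72 h (a lower number here means a stronger inhibitor, a higher number a weaker inhibitor), compound 1 gives only a limit, > 20000 nM, and no number. Among the three values shown, compound 1 thus stands at the weak end (the limit of > 20000 nM in this assay, at which 1 of the 3 values shown sits). Going by the values given here, compound 3 `C#Cc1cn([C@@H]2O[C@H](CO)[C@@H](O)[C@H]2O)c2ncnc(N(C)C)c12`, which carries ethynyl in place of 1-benzofuran-2-yl, gives 90 nM in this assay, and the step of an at least 220-fold lower number from compound 1 to compound 3 (2.34 log units; beyond the scatter) is the only measured step in the set. Compound 2 `O=c1[nH]cnc2c1c(-c1ccsc1)cn2[C@@H]1O[C@H](CO)[C@@H](O)[C@H]1O`, with a thiophen-3-yl group and an oxo group in place of the amine, gives 14500 nM in this assay.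

Compound 4 `CNc1ncnc2c1c(-c1cc3ccccc3o1)cn2[C@@H]1O[C@H](CO)[C@@H](O)[C@H]1O` is made from compound 1 by the change (hydrogen in place of methyl on a nitrogen on an aromatic ring). Among the compounds with values here, none of the measured steps touches this nitrogen, so nothing in the data tells how large a step to expect, in either direction. Since compound 1 sits at a limit, the step from compound 1 is estimated as an at least 1.3-fold lower number from compound 1 to compound 4 (0.12 log units; that floor lies within the scatter), with the chance of a number remaining uncertain. Compound 4 is therefore expected to give about 15000 nM in this assay, within the range 2000 nM to 40000 nM.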

Compound 4, half-maximal inhibitory concentration: > 20000 nM
Compound 4: a limit, no number; the forecaster's own chance of this, stated with the estimate: 50%; middle value at least 1.3-fold (0.12 log units) away from the limit.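

In this assay compound 4 gives > 20000 nM as a limit and not a number. Going by these compounds alone, compound 1 also stands at a limit, so no step from compound 1 to compound 4 can be read: the limit of > 20000 nM in this assay, at which 2 of the 4 values shown sit. The compounds shown leave open how far compound 1 and compound 4 lie beyond that limit, and whether hydrogen in place of methyl on this nitrogen changes the result at all.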